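Paw edema inhibition in a thiazolidinone series

This account rests on a few compounds, and the source may have more. Where it says the series, first, only, none or still open, it means among the compounds named here.

Measured compounds:
compound 1 `Cc1nc(-c2ccc(Cl)cc2)sc1C1SCC(=O)N1c1ccc(F)c(Cl)c1`: 45.2%
compound 2 `Cc1nc(-c2ccccc2)sc1C1SCC(=O)N1c1ccc(F)c(Cl)c1`: 20.9%
compound 3 `Cc1nc(Cc2ccc(Cl)cc2)sc1C1SCC(=O)N1c1ccccc1`: "not active" (no number reported)

In a functional assay on the whole organism (strain Wistar albino) for inhibition, with Rattus norvegicus as the target, read by paw edema, with stated times of 1 h and 2 h, at a dose of 40 mg/kg by the oral route (on this read-out higher numbers stand for more inhibition at the one dose given (going by the name of the read-out) and lower numbers for less inhibition), compound 1 gives 45.2% and compound 2 gives 20.9%. The step of a number 24.3 percentage points higher from compound 2 to compound 1 (beyond the scatter) corresponds to chloro in place of hydrogen on an aromatic carbon. In this assay compound 3 is reported as "not active" (no number reported), with no number behind it. The difference between the core of compound 2 and the core of compound 3 is not broken down here.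

Compound 4 `Cc1nc(Cc2ccc(Cl)cc2)sc1C1SCC(=O)N1c1ccc(Cl)cc1` is not yet measured. It differs from compound 3 by chloro in place of hydrogen on an aromatic carbon, the same change as seen once before, where it made the step of a number 24.3 percentage points higher from compound 2 to compound 1 (beyond the scatter). Compound 3 gives no numerical starting point, so the expectation rests on a single earlier step only. On that basis compound 4 is expected to give about 22% in this assay. For compound 4 the estimated range runs from 5% to 40%, and a report of no number at all remains plausible.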

Compound 4, a percentage reported as inhibition, in the whole organism at one dose (the size of the read-out at that dose, not a potency): 40.1%
Estimate against measurement, compound 4: 18.1 percentage points below; the whole stated range lies below it.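

In this assay, within the data shown here, compound 4 gives 40.1% but compound 3 has no number, so no step between them can be read. From the compounds shown here alone, the size of the phenyl to 4-chlorophenyl change in this pair stays open. No evidence shown bears on this result.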